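This account rests on a few compounds, and the source may have more. Where it says the series, first, only, none or still open, it means among the compounds named here.

Compound 1 `Cc1oc(-c2ccc(Cl)cc2)nc1CN1CCC(C(=O)NCCCN2C[C@H](C)C[C@H](C)C2)CC1` has a number in an ADME assay on Huh7.5.1 cells (Homo sapiens) for cytotoxicity, read by ATP content, with a stated time of 48 h (on this read-out lower numbers stand for higher toxicity in this test and higher numbers for lower toxicity in this test), where compound 1 gives 11500 nM. Within the data shown here, the only other compound of the series with a number there is compound 2 `Cc1ccccc1-c1nc(CN2CCC(C(=O)N3CCN(C4CCN(C)CC4)CC3)CC2)c(C)o1`, which gives 19900 nM in this assay; the two values lie within the scatter of each other, so neither compound is set apart from the other on half-maximal cytotoxic concentration. Among the measured compounds shown here, no pair of measured compounds differs in one place, so no step size for a single change has been seen yet. Compound 3 `Cc1ccc(-c2nc(CN3CCC(C(=O)NCCCN4C[C@H](C)C[C@H](C)C4)CC3)c(C)o2)cc1C` differs from compound 1 in one place: 3,4-dimethylphenyl in place of 4-chlorophenyl on an aromatic carbon. For the measured compounds named here, nothing among the measured compounds points to a change in cytotoxicity from such an exchange, so the step of a 1.0-fold higher number from compound 1 to compound 3 (0.02 log units; within the scatter) implied by the estimate is expected to stay within the scatter, with no set direction. For compound 3 the expected value in this assay is 12000 nM, within a range from 5000 nM to 30000 nM.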

Compound 3, half-maximal cytotoxic concentration: 6910 nM
Compound 3: middle estimate off by 1.7-fold (0.24 log units), on the high side; the range from low to high includes it.
By their numbers in this assay, from the lowest: compounds 3, 1 and 2 (each within the scatter of the next, the first and the last beyond it).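

Among these compounds, this is the first step read at a single place: on the aromatic carbon of the five-membered aromatic ring with 1 nitrogen and 1 oxygen, 3,4-dimethylphenyl in place of 4-chlorophenyl gives a 1.7-fold lower number from compound 1 to compound 3 (0.22 log units; within the scatter) in this assay. At this place, then, an aryl group of carbon only, with 8 heavy atoms, and one bearing chlorine, with 7, are not told apart by this read-out, and the step sets no direction. Nothing at hand bears on why the two groups compare as they do.

Open, from the compounds shown here alone, is whether a group of another kind on that aromatic ring, such as an amine or a carboxylic acid, would give a step beyond the scatter. Also open, going by these compounds, is whether the same exchange gives a step of similar size on the core of compound 2.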